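This account rests on a few compounds, and the source may have more. Where it says the series, first, only, none or still open, it means among the compounds named here.

Working notes on the series. Of the compounds shown here, three have been measured in a functional assay (aorta) for inhibition, with Rattus norvegicus as the target; on this read-out higher numbers stand for weaker inhibition and lower numbers for stronger inhibition. Compound 1 `CC1(C)CC(NC(=O)Nc2ccccc2)c2cc(C#N)ccc21` gives 1300000 nM in this assay. Compound 2 `CC1(C)CN(C(=O)Nc2cccnc2)c2cc(C#N)ccc21` gives 1500000 nM in this assay. Compound 3 `CC(C)(C)c1ccc(C#N)cc1NC(=O)Nc1ccccc1` gives 1700000 nM in this assay, the highest of the three numbers, though its gaps to compound 2 and to compound 1 both lie within the usual scatter, so no order among the three can be read from these values. Going by the values given here, no pair among them differs in one place only, so no single step between measured compounds is available.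

Compound 4 `CC(C)(C)c1ccc(C#N)cc1NC(=O)Nc1cnccn1` has not been measured in this assay. It differs from compound 3 in one place: pyrazin-2-yl in place of phenyl on an amide-type nitrogen. Among the compounds with values here, no measured pair isolates this exchange, and the three measured values all sit close together, so the step from compound 3 to compound 4 is expected to fall within the scatter, with no direction beyond it, as no change at the digits printed from compound 3 to compound 4 (within the scatter). Compound 4 is accordingly estimated at 1700000 nM in this assay, within a range from 500000 nM to 5000000 nM.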

Compound 4, half-maximal inhibitory concentration: 15300000 nM
The estimate for compound 4 lay 9.0-fold (0.95 log units) below the measured number; measured number outside the range, above it.
By their numbers in this assay, from the lowest: compounds 1, 2 and 3 (each within the scatter of the next); then compound 4.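

In this assay, going by these compounds alone, the amide-type nitrogen is the first place where a single exchange moves the number beyond the scatter: pyrazin-2-yl in place of phenyl gives a 9.0-fold higher number from compound 3 to compound 4 (0.95 log units; beyond the scatter), which means weaker inhibition. The earlier compounds shown here lie within the scatter of one another and include no pair differing in one place, so they could not show that this position responds to a change of ring. Nothing at hand accounts for the size or direction of this step.

On these data alone, whether a pyridin-2-yl or pyrimidin-2-yl ring on this nitrogen would read like phenyl or like pyrazin-2-yl stays open, as does the effect of an amine or a carboxylic acid on the phenyl ring. Also open, as far as these compounds go, is whether the same exchange would give a similar step on the cores of compound 1 and compound 2.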